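Adding a second methoxy: from compound 3 to compound 4

The source may hold more compounds than are shown below. What is called first, only, known or untested is meant among the compounds shown, and "the series" means these compounds.

Measured in an assay on CHO cells for displacement of a labelled ligand from adenosine receptor A1 (Homo sapiens), read by scintillation counting, with a stated time of 1 h, tested at 1 uM; a lower number here means less inhibition, a higher number more inhibition at the concentration tested (going by the name of the read-out):
compound 1, `Nc1ncc(-c2ccccc2)c(-c2ccccc2)n1`: 32%
compound 2, `Nc1ncc(-c2cccc(F)c2)c(-c2ccccc2)n1`: 63%
compound 3, `COc1cccc(-c2cnc(N)nc2-c2ccccc2)c1`: a limit of > 80%

Compound 3 sits at the limit of > 80% in this assay, at which 1 of the 3 values shown sits, so for compound 3 only a limit and no number is known, and it can only be said to stand at or beyond the top of the three values shown. The steps that lead to it are both large: a number at least 48 percentage points higher from compound 1 to compound 3 (beyond the scatter), with methoxy in place of hydrogen on an aromatic carbon, and a number at least 17 percentage points higher from compound 2 to compound 3 (beyond the scatter), with methoxy in place of fluoro on an aromatic carbon. The step of a number 31 percentage points higher from compound 1 to compound 2 (beyond the scatter) shows that fluoro in place of hydrogen on an aromatic carbon also raises the read-out.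

Compound 4, `COc1ccc(-c2cnc(N)nc2-c2ccccc2)cc1OC`, differs from compound 3 in one place: methoxy in place of hydrogen on an aromatic carbon. The two measured steps that introduce methoxy bear on this change and were large, but compound 3 is already at the limit, so no further rise can be read off, and a result at the same limit is expected again. The step that the limit leaves unreadable from compound 3 to compound 4 is therefore expected to lie within the scatter. Compound 4 is expected to give about 85% in this assay, with a range from 60% to 100%.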

Compound 4, a percentage reported as inhibition, at one concentration (the size of the read-out at that concentration, not a potency): > 80%
Compound 4: only a limit was reported; the forecaster's own chance of this, stated with the estimate: 60%; the middle value is on the limit's open side.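

In this assay compound 4 gives > 80% as a limit of the assay, not a number. Compound 3 also stands at a limit, so no step can be read from compound 3 to compound 4. The compounds shown leave open whether the added methoxy changes the inhibition at all, and how compound 3 and compound 4 would rank.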